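The compounds below may be only part of what the source reports. "The series", "measured", "known", "first", "only" and "open" are said of these compounds alone.

Compound 1 `CN(C)/C=C/C(=O)c1ccc2c(c1)CCCC2`: 22.3 ug/mL
Compound 2 `O=C(/C=C\Nc1ccccc1)c1ccc2c(c1)CCCC2`: 19.9 ug/mL

In a functional assay on HepG2 cells (Homo sapiens) for cytotoxicity, read by MTT assay, with a stated time of 48 h (a lower number here means a stronger inhibitor, a higher number a weaker inhibitor), compound 2 gives 19.9 ug/mL, which lies within the scatter of compound 1, so the two cannot be told apart. Compound 3 `O=C(/C=C\Nc1ccc(Cl)cc1)c1ccc2c(c1)CCCC2` is compound 2 with chloro in place of hydrogen on an aromatic carbon, para to a large group, turning phenyl to 4-chlorophenyl: chloro in place of hydrogen on an aromatic carbon. Within the data shown here, no measured step shows what such a change does in this assay. A modest move toward a lower number is expected, perhaps not clearly beyond the scatter, and the estimated step is a 1.4-fold lower number from compound 2 to compound 3 (0.15 log units; within the scatter). The expected value for compound 3 is 14 ug/mL, within an estimated range of 6 ug/mL to 30 ug/mL.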

Compound 3, half-maximal inhibitory concentration: 30.3 ug/mL
Beside the measured number, compound 3's estimate is 2.2-fold (0.34 log units) below it; measured number above the stated range.
By their numbers in this assay, from the lowest: compounds 2, 1 and 3 (each within the scatter of the next).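

In this assay, chloro in place of hydrogen on an aromatic carbon, para to a large group, gives a 1.5-fold higher number from compound 2 to compound 3 (0.18 log units; within the scatter). This is the only single-place change shown, and turning phenyl to 4-chlorophenyl does not separate the two compounds in this test. Nothing measured here bears on the reason for this result. From the compounds shown here alone, what remains open is whether a different group in the same place, such as methoxy or a carboxylic acid, would move the number beyond the scatter.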